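A few compounds are considered here, and "the series" means these few. Any claim that something is new, unique, unknown or untested is made for them only; others in the source may bear on it.

Compound 2 `CC(=O)Oc1ccccc1C(=O)O[C@H]1CO[C@H]2[C@@H]1OC[C@H]2OC(=O)c1ccc(C)cc1` has been measured in an ADME assay on a cell-free system (plasma, Homo sapiens) for metabolic stability, with Plasma (Rattus norvegicus) as the target, read by HPLC, at pH 7.4 (on this read-out lower numbers stand for a shorter-lived compound and higher numbers for a longer-lived compound), where compound 2 gives 0.105 h. Among the measured compounds shown here, only one other compound shares this read-out: compound 1 `CC(=O)Oc1ccccc1C(=O)O[C@H]1CO[C@H]2[C@@H]1OC[C@H]2OC(=O)c1ccccc1`, which in this assay gives 0.055 h. Compound 2 therefore stands alongside compound 1 rather than apart from it, since a 1.9-fold higher number from compound 1 to compound 2 (0.28 log units; within the scatter) does not exceed the scatter of the measurement.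

Compound 3 `CC(=O)Oc1ccccc1C(=O)O[C@H]1CO[C@H]2[C@@H]1OC[C@H]2OC(=O)c1cnccc1Cl` is the next compound in this series, not yet measured. It differs from compound 2 by 4-chloropyridin-3-yl in place of 4-methylphenyl on a carbonyl carbon. For the measured compounds named here, the single step measured so far, a 1.9-fold higher number from compound 1 to compound 2 (0.28 log units; within the scatter), touches the same ring but changes only a methyl for a hydrogen, and it was within the scatter; no measured step exchanges the whole ring. On that thin basis no step beyond the scatter is expected in this assay for compound 3, and the estimate is 0.08 h, within 0.03 h to 0.25 h. This estimate corresponds to an expected 1.3-fold lower number from compound 2 to compound 3 (0.12 log units; within the scatter).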

Compound 3, half-life: 0.0642 h
Estimate against measurement, compound 3: 1.2-fold (0.10 log units) above; measured number inside the range.
By their numbers in this assay, from the lowest: compounds 1, 3 and 2 (each within the scatter of the next).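

In this assay, exchanging the whole ring on the carbonyl carbon, rather than only a methyl for a hydrogen, gives a 1.6-fold lower number from compound 2 to compound 3 (0.21 log units; within the scatter) and, against the phenyl compound, a 1.2-fold higher number from compound 1 to compound 3 (0.07 log units; within the scatter). At this position, therefore, 4-chloropyridin-3-yl, which brings a ring nitrogen, a chlorine and a hydrogen-bond acceptor, leaves the half-life within the scatter of both 4-methylphenyl and phenyl, so compound 1, compound 2 and compound 3 cannot be told apart on this read-out. No measured evidence is available to account for this result.

From the compounds shown here alone, all three compounds carry a six-membered aromatic ring at this place, so it remains open whether any group here can move the half-life beyond the scatter. An amine or a carboxylic acid on that ring, or a longer chain in its place, could answer that question.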